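Acetamido on the phenyl of compound 1

This account rests on a few compounds, and the source may have more. Where it says the series, first, only, none or still open, it means among the compounds named here.

Measured so far:
compound 1 `C[C@@H](NCC1CCN(CCCc2c[nH]c3ccc(-n4cnnc4)cc23)CC1)c1ccccc1` gives 14 nM
compound 2 `CC(C)=CCCN(C)C1CCN(CCCc2c[nH]c3ccc(-n4cnnc4)cc23)CC1` gives 24 nM
compound 3 `O[C@@H]1Cc2ccccc2[C@H]1NC1CCN(CCCc2c[nH]c3ccc(-n4cnnc4)cc23)CC1` gives 210 nM

In an assay on CHO cells for displacement of a labelled ligand from 5-hydroxytryptamine receptor 1B (Homo sapiens) (a higher number here means a weaker inhibitor, a lower number a stronger inhibitor), compound 1 holds the lowest of the three numbers. One neighbour sits within the scatter of it, a 1.7-fold higher number from compound 1 to compound 2 (0.23 log units; within the scatter); the other lies clearly beyond, a 15-fold higher number from compound 1 to compound 3 (1.18 log units; beyond the scatter), as does an 8.8-fold higher number from compound 2 to compound 3 (0.94 log units; beyond the scatter). Every one of these steps exchanges the whole amine side chain on the saturated ring carbon.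

Compound 4 `CC(=O)Nc1ccc([C@@H](C)NCC2CCN(CCCc3c[nH]c4ccc(-n5cnnc5)cc34)CC2)cc1` differs from compound 1 by acetamido in place of hydrogen on an aromatic carbon. Within the data shown here, no measured step touches a substituent on that phenyl ring, so none bears directly on this change; the series offers no precedent either way. With the side chain otherwise kept as in compound 1, a step within the scatter is expected, a 1.4-fold higher number from compound 1 to compound 4 (0.15 log units; within the scatter). Compound 4 is therefore estimated at 20 nM, with a range from 6 nM to 70 nM.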

Compound 4, half-maximal inhibitory concentration: 8.9 nM
For compound 4 the middle estimate is 2.2-fold (0.35 log units) above the measured one, and the stated range covers the measured number.
By their numbers in this assay, from the lowest: compounds 4, 1 and 2 (each within the scatter of the next, the first and the last beyond it); then compound 3.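

Acetamido on the carbon para to a large group is accepted on the phenyl of compound 1: in this assay the change gives a 1.6-fold lower number from compound 1 to compound 4 (0.20 log units; within the scatter), so the two numbers cannot be told apart. Unlike the earlier steps, which exchange the whole amine side chain, this one alters only a substituent on that ring. No available data explain this result.

On these data alone, whether an amine or a carboxylic acid at this carbon would read the same remains open. So does the reading for a longer acylamino chain there.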